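Butylamino for diethylamino on the amide of compound 2

A few compounds are considered here, and "the series" means these few. Any claim that something is new, unique, unknown or untested is made for them only; others in the source may bear on it.

Measured compounds:
compound 1 `COc1cc2c(cc1OC)C(CC(=O)N(C)C)CC2`: 23.3%
compound 2 `CCN(CC)C(=O)CC1CCc2cc(OC)c(OC)cc21`: 16.7%

Two amides of the shared core have been tested in a functional assay on the whole organism (strain Wistar) for inhibition, with Rattus norvegicus as the target, read by paw edema, with stated times of 60 min and 24 h, at a dose of 100 mg/kg by the oral route; a lower number here means less inhibition, a higher number more inhibition at the dose given (going by the name of the read-out). Compound 1 `COc1cc2c(cc1OC)C(CC(=O)N(C)C)CC2` gives 23.3% in this assay, and compound 2 `CCN(CC)C(=O)CC1CCc2cc(OC)c(OC)cc21` gives 16.7%. Within the data shown here, the one step measured, a number 6.6 percentage points lower from compound 1 to compound 2 (within the scatter), stays within the scatter, so the two numbers cannot be told apart and compound 2 stands level with compound 1 on what is known.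

Compound 3 `CCCCNC(=O)CC1CCc2cc(OC)c(OC)cc21` is yet to be measured. It differs from compound 2 in one place: butylamino in place of diethylamino on a carbonyl carbon. Among the measured compounds shown here, no measured step matches this change, since the only step known exchanges one amine for another on the carbonyl carbon without introducing a hydrogen-bond donor, and that step, a number 6.6 percentage points lower from compound 1 to compound 2 (within the scatter), was within the scatter. On this basis no step beyond the scatter is expected, and the change from compound 2 to compound 3 is estimated at a number 3.3 percentage points higher from compound 2 to compound 3 (within the scatter) in this assay. Compound 3 is therefore expected to give 20%, within a range from 5% to 35%.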

Compound 3, a percentage reported as inhibition, in the whole organism at one dose (the size of the read-out at that dose, not a potency): 36.7%
For compound 3 the middle estimate is 16.7 percentage points below the measured one; the whole stated range lies below it.
By their numbers in this assay, from the lowest: compounds 2 and 1 (each within the scatter of the next); then compound 3.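

In this assay, the place on the carbonyl carbon now gives a step beyond the scatter, which the exchange of dimethylamino for diethylamino did not: butylamino in place of diethylamino gives a number 20 percentage points higher from compound 2 to compound 3 (beyond the scatter), and butylamino in place of dimethylamino gives a number 13.4 percentage points higher from compound 1 to compound 3 (beyond the scatter) here. So the amine on this carbonyl carbon can matter to this read-out, and the two groups with no amide hydrogen sit apart from the one group that has it. Butylamino and diethylamino hold the same atoms joined differently, so the step comes with both an unbranched chain on the nitrogen and a new amide hydrogen, and these two differences cannot be separated with the compounds shown; no measurement at hand gives a reason for the step.

On these data alone, what stays open is whether the amide hydrogen alone carries the step, which ethylamino or hexylamino on the same carbonyl carbon would help to show, along with how the chain length counts. A ring amine such as piperidine, or N-methylbutylamino, which keeps the butyl chain without the amide hydrogen, would also separate the two differences.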